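Removing a Methyl from a Ring Oxygen: Compound 3

A few compounds are considered here, and "the series" means these few. Any claim that something is new, unique, unknown or untested is made for them only; others in the source may bear on it.

Measured so far:
compound 1 `Cc1cc(O)cc(-c2nn(CC#N)cc2-c2ccnc(-c3ccc(Oc4ccccc4)cc3)c2)c1`: -97%
compound 2 `COc1cc(C)cc(-c2nn(CC#N)cc2-c2ccnc(-c3ccc(N(C)C)cc3)c2)c1`: -44%

Of the compounds shown here, two have been tested in a functional assay on HCT-116 cells (Homo sapiens) for cytotoxicity, read by sulforhodamine B assay, with a stated time of 48 h, tested at 10 uM; on this read-out higher numbers stand for a weaker effect at the one concentration tested and lower numbers for a stronger effect. Compound 1 gives -97% and compound 2 gives -44%, so compound 2 stands as the higher of the two numbers, with a gap to compound 1 that lies beyond the usual scatter. These two compounds differ in more than one place, so their gap cannot be tied to any single change.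

Compound 3 `Cc1cc(O)cc(-c2nn(CC#N)cc2-c2ccnc(-c3ccc(N(C)C)cc3)c2)c1` is the next compound to be measured. Its change from compound 2 is hydrogen in place of methyl on an oxygen on an aromatic ring. Compound 1 carries the same hydroxy group and gives the lower number, but it also differs elsewhere, so no clean comparison exists. The step from compound 2 to compound 3 is expected to be small, perhaps a modest move toward a lower number, as a number 16 percentage points lower from compound 2 to compound 3 (beyond the scatter). Compound 3 is estimated at -60%, within -95% to -25%.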

Compound 3, a percentage reported as activity, at one concentration (the size of the read-out at that concentration, not a potency): -81%
For compound 3 the middle estimate is 21 percentage points above the measured one; the range from low to high includes it.
By their numbers in this assay, from the lowest: compound 1; then compound 3; then compound 2.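

In this assay, methoxy to hydroxy on the aromatic ring gives a number 37 percentage points lower from compound 2 to compound 3 (beyond the scatter), so what sits on this oxygen clearly matters: losing one methyl goes with a stronger effect at the one concentration tested. With the hydroxy held constant, dimethylamino in place of phenoxy gives a number 16 percentage points higher from compound 1 to compound 3 (beyond the scatter), showing that the group at the other end of the molecule also counts, though this step is only modest. Nothing available explains either step.

Still open, from the compounds shown here alone, is whether a free hydroxy is what counts on this ring, or whether an amine or a carboxylic acid in its place would give a similar number. Going by these compounds, it is also open whether the hydroxy step would have the same size with phenoxy in place of dimethylamino.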